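The compounds below may be only part of what the source reports. "The series", "measured", "known", "first", "only" and "open" are said of these compounds alone.

Compound 1, `COc1ccc(-c2[nH]c3ccc(C(C)C)cc3c2C=O)cc1`, is the starting point of this set. In a functional assay on MCF7 cells (Homo sapiens) for antiproliferative activity, with a stated time of 5 days (a lower number here means a stronger inhibitor, a higher number a weaker inhibitor), compound 1 gives 97 nM. Compound 2, `COc1ccc(-c2[nH]c3ccc(C(C)(C)C)cc3c2C=O)cc1`, carries the change (methyl in place of hydrogen on a saturated chain carbon bound to an aromatic carbon and two saturated chain carbons). In this assay compound 2 gives 580 nM, and the step of a 6.0-fold higher number from compound 1 to compound 2 (0.78 log units; beyond the scatter) is therefore a loss of potency.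

Compound 3, `CCCCCc1ccc2[nH]c(-c3ccc(C(F)(F)F)cc3)c(C=O)c2c1`, belongs to a different core, and the difference between the core of compound 1 and the core of compound 3 is not broken down here. In this assay compound 3 gives 67 nM, which sits within the scatter of compound 1 and well apart from compound 2.

Compound 4, `CCCCCCc1ccc2[nH]c(-c3ccc(C(F)(F)F)cc3)c(C=O)c2c1`, has not yet been measured. It differs from compound 3 by methyl in place of hydrogen on a saturated chain carbon, five bonds along the chain from an aromatic carbon. Among the compounds with values here, this is the same kind of change as the one from compound 1 to compound 2, but not the same: there the new methyl entered on a saturated chain carbon bound to an aromatic carbon and two saturated chain carbons, whereas here it enters on a saturated chain carbon five bonds along the chain from an aromatic carbon, so that the pentyl chain is simply lengthened to a hexyl chain. Because the earlier step of a 6.0-fold higher number from compound 1 to compound 2 (0.78 log units; beyond the scatter) arose at a branched position, it is not expected to carry over in full. The step from compound 3 to compound 4 in this assay is estimated at a 1.3-fold higher number from compound 3 to compound 4 (0.13 log units; within the scatter). Compound 4 is therefore expected to give about 90 nM, with a likely range of 35 nM to 250 nM.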

Compound 4, half-maximal inhibitory concentration: 22 nM
Compound 4: the middle estimate sits 4.1-fold (0.61 log units) above what was measured; measured number below the stated range.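

In this assay, the step of a 3.0-fold lower number from compound 3 to compound 4 (0.48 log units; beyond the scatter) is a gain in potency: lengthening the pentyl chain to a hexyl chain strengthens the compound, whereas the earlier methyl step weakened it. Methyl in place of hydrogen therefore does not carry over from the core of compound 1 to the core of compound 3 in either size or direction: the same change on two cores in this assay, a 6.0-fold higher number (0.78 log units; beyond the scatter) from compound 1 to compound 2 and a 3.0-fold lower number (0.48 log units; beyond the scatter) from compound 3 to compound 4, 18-fold (1.26 log units) apart, beyond the scatter of two such steps This does not show that the core alone sets the outcome, since the two steps also differ in where the methyl enters, on a saturated chain carbon bound to an aromatic carbon and two saturated chain carbons in one case and five bonds along the chain from an aromatic carbon in the other, and the two pairs cannot tell these influences apart.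

The compounds shown leave open how a pentyl or hexyl chain would behave on the core of compound 1, and how a tert-butyl group or a longer chain such as heptyl would behave on the core of compound 3. They also leave open what a nitrile or a carboxylic acid in place of the carbonyl group would do on either core.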